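Varying the Ketone Substituent on a Furyl-Bearing Core

The source may hold more compounds than are shown below. What is called first, only, known or untested is meant among the compounds shown, and "the series" means these compounds.

Compound 1 `CC1=C(C(=O)OC(C)(C)C)C(c2ccoc2)NC(=O)N1`: 11%
Compound 2 `CC1=C(C(=O)C2CC2)C(c2ccoc2)NC(=O)N1`: 1%

Within the data shown here, in an assay on membranes from CHO cells for displacement of a labelled ligand from adenosine receptor A1 (Homo sapiens), read by scintillation counting, with a stated time of 60 min, tested at 1 uM (on this read-out higher numbers stand for more inhibition at the one concentration tested (going by the name of the read-out) and lower numbers for less inhibition), compound 2 stands at 1%, and compound 1 at 11% lies within the scatter of it; the one measured step, a number 10 percentage points lower from compound 1 to compound 2 (within the scatter), does not leave that scatter. Compound 3 `CC1=C(C(=O)CC(C)C)C(c2ccoc2)NC(=O)N1` carries isobutyl in place of cyclopropyl on a carbonyl carbon. That earlier step also changed the group on the same carbonyl carbon of the shared core, so for compound 3 a step of a number 4 percentage points higher from compound 2 to compound 3 (within the scatter) is expected, none beyond the scatter. Compound 3 is therefore estimated at 5%, with a range from -5% to 15%.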

Compound 3, a percentage reported as inhibition, at one concentration (the size of the read-out at that concentration, not a potency): 23%
Estimate against measurement, compound 3: 18 percentage points below; measured number outside the range, above it.
By their numbers in this assay, from the lowest: compounds 2 and 1 (each within the scatter of the next); then compound 3.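

On the carbonyl carbon of the shared core, the choice of group does register in this assay: isobutyl in place of cyclopropyl gives a clear rise (a number 22 percentage points higher from compound 2 to compound 3 (beyond the scatter)), and isobutyl in place of tert-butoxy gives another (a number 12 percentage points higher from compound 1 to compound 3 (beyond the scatter)). Compound 3 therefore separates from both earlier compounds, which the earlier step alone had not done for any pair. Nothing available explains why isobutyl stands apart. Going by these compounds, whether the open chain or the chain's branching goes with the higher number stays open, and a straight butyl chain or a cyclobutyl ring would bear on that. How an amine on this carbonyl carbon would read is also unknown.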